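Chloro for hydrogen carried from one core to a second

The source may hold more compounds than are shown below. What is called first, only, known or untested is meant among the compounds shown, and "the series" means these compounds.

Compound 1 `COC(=O)C1=C(N)Oc2ccc(Br)cc2C1CC(=O)c1ccccc1` gives 41.3% in a functional assay on MCF7 cells (Homo sapiens) for antiproliferative activity, read by sulforhodamine B assay, with a stated time of 72 h, tested at 30 uM; on this read-out lower numbers stand for a stronger effect and higher numbers for a weaker effect at the one concentration tested. Compound 2 `COC(=O)C1=C(N)Oc2ccc(Br)cc2C1CC(=O)c1ccc(Cl)cc1` gives 32.4% in this assay; the change, (chloro in place of hydrogen on an aromatic carbon), made the step of a number 8.9 percentage points lower from compound 1 to compound 2 (within the scatter). Compound 3 `COc1cc(Br)cc2c1OC(N)=C(C#N)C2CC(=O)c1ccccc1` gives 36.7% in this assay; the difference between its core and that of compound 1 is not broken down here, and its value and those of compounds 1 and 2 lie within the scatter of one another. Compound 4 `COc1cc(Br)cc2c1OC(N)=C(C#N)C2CC(=O)c1ccc(Cl)cc1` carries the same change, (chloro in place of hydrogen on an aromatic carbon), on the core of compound 3; the place is described in the same words both times. For the measured compounds named here, only one earlier instance, the step from compound 1 to compound 2 a number 8.9 percentage points lower from compound 1 to compound 2 (within the scatter), gives any hold, so a step of a number 6.7 percentage points lower from compound 3 to compound 4 (within the scatter) is expected. Compound 4 is estimated at 30% in this assay, with 18% to 44% as the expected range.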

Compound 4, a percentage reported as activity, at one concentration (the size of the read-out at that concentration, not a potency): 33.3%
For compound 4 the middle estimate is 3.3 percentage points below the measured one; the range from low to high includes it.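

In this assay, phenyl to 4-chlorophenyl on the second core reads as a number 3.4 percentage points lower from compound 3 to compound 4 (within the scatter). Set beside the step on the first core, the two do not differ: the same change on two cores in this assay, a number 8.9 percentage points lower (within the scatter) from compound 1 to compound 2 and a number 3.4 percentage points lower (within the scatter) from compound 3 to compound 4, 5.5 percentage points apart, within the scatter of two such steps. This shows that the change carries across these two cores without a step beyond the scatter on either, but it does not show that chloro has a real effect on this read-out, and one pair of steps establishes no rule for other cores.

Open, going by these compounds, is whether another group at the same place, such as an amine, a carboxylic acid or a longer chain, would give a step beyond the scatter. The cores of compound 1 and compound 3 differ in more than one place, so the methyl ester, the nitrile and the methoxy group remain unseparated.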